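A few compounds are considered here, and "the series" means these few. Any claim that something is new, unique, unknown or untested is made for them only; others in the source may bear on it.

Working notes on the series. Compound 3 `C[C@@H]1CCCN1c1c(C#N)c2c(N)nc(Nc3cn[nH]c3)nc2n1C` gives the lowest number of the three in an assay on isolated protein for inhibition of Leucine-rich repeat serine/threonine-protein kinase 2 (Homo sapiens), read by TR-FRET and LanthaScreen, with stated times of 50 min and 30 min, in the presence of a further agent that is not named here (a lower number here means a stronger inhibitor, a higher number a weaker inhibitor), at 6 nM. Compound 2 `Cc1nn(C)cc1Nc1nc(N)c2c(C#N)c(N3CCC[C@H]3C)n(C)c2n1` gives 38 nM, and compound 1 `Cc1c(Nc2nc(N)c3c(C#N)c(N4CCC[C@H]4C)n(C)c3n2)cnn1CC(C)(C)O` gives 43 nM. Within the data shown here, the only single-point step known runs a 6.3-fold lower number from compound 2 to compound 3 (0.80 log units; beyond the scatter). Compound 4 `Cc1c(Nc2nc(N)c3c(C#N)c(N4CCC[C@H]4C)n(C)c3n2)cnn1C1COC1` differs from compound 3 by 5-methyl-1-(oxetan-3-yl)-1H-pyrazol-4-yl in place of 1H-pyrazol-4-yl on a nitrogen on an aromatic ring. Among the measured compounds shown here, no measured step carries exactly this change; the step from compound 2 to compound 3 shows that removing the methyls from the pyrazole lowered the number, and compound 1, which also bears a substituted pyrazole, sits near compound 2. Compound 4 is therefore expected to move upward, by an estimated 5.8-fold higher number from compound 3 to compound 4 (0.77 log units; beyond the scatter), giving an estimate of 35 nM with a range of 12 nM to 100 nM.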

Compound 4, half-maximal inhibitory concentration: 47 nM
Estimate against measurement, compound 4: 1.3-fold (0.13 log units) below; the measured number falls inside the stated range.
By their numbers in this assay, from the lowest: compound 3; then compounds 2, 1 and 4 (each within the scatter of the next).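

In this assay, 5-methyl-1-(oxetan-3-yl)-1H-pyrazol-4-yl in place of 1H-pyrazol-4-yl gives a 7.8-fold higher number from compound 3 to compound 4 (0.89 log units; beyond the scatter), so a third substituted pyrazole also sits apart from the unsubstituted one. The substituted pyrazoles do not separate from one another, with a 1.2-fold higher number from compound 2 to compound 4 (0.09 log units; within the scatter) and a 1.1-fold higher number from compound 1 to compound 4 (0.04 log units; within the scatter), so neither oxetan-3-yl nor its exchange for 1,3-dimethyl or 2-hydroxy-2-methylpropyl shifts the number measurably here. Nothing at hand explains the result. The compounds shown leave open whether the 5-methyl alone accounts for the step from the unsubstituted pyrazole. They also leave open how a pyrazole bearing an aminoethyl chain or a carboxylic acid would compare.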